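The source may report more compounds than this note shows. Statements on the series, on what has been measured and on what is new or still open speak of the compounds shown alone.

Three analogues sharing one core were compared in a functional assay on WM 266-4 cells (Homo sapiens) for antiproliferative activity, read by MTT assay, with a stated time of 48 h; on this read-out lower numbers stand for stronger inhibition of growth and higher numbers for weaker inhibition of growth. Compound 1 `Cc1ccc(C2=NN(C(=S)Nc3ccccc3)C(c3ccc4c(c3)OCCO4)C2)cc1` gives 10300 nM, the lowest of the three numbers. Compound 2 `FC(F)(F)c1ccc(C2=NN(C(=S)Nc3ccccc3)C(c3ccc4c(c3)OCCO4)C2)cc1` gives 52400 nM, and compound 3 `COc1ccccc1C1=NN(C(=S)Nc2ccccc2)C(c2ccc3c(c2)OCCO3)C1` gives 25800 nM. Among the steps between them, a 5.1-fold higher number from compound 1 to compound 2 (0.71 log units; beyond the scatter) is the largest, a 2.5-fold higher number from compound 1 to compound 3 (0.40 log units; beyond the scatter) is smaller, and a 2.0-fold lower number from compound 2 to compound 3 (0.31 log units; beyond the scatter) runs the other way.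

Compound 4 `COc1cccc(C2=NN(C(=S)Nc3ccccc3)C(c3ccc4c(c3)OCCO4)C2)c1` has not yet been measured. It differs from compound 1 in one place: 3-methoxyphenyl in place of 4-methylphenyl on a carbon with a double bond to nitrogen. The step with most bearing on this change is a 2.5-fold higher number from compound 1 to compound 3 (0.40 log units; beyond the scatter), which also places a methoxyphenyl, there the 2-methoxyphenyl, on that carbon. Within the data shown here, a 3-methoxyphenyl on that carbon has no direct precedent in this set, so the expectation is read from that neighbouring step and its modest size. For compound 4 the expected step is a 1.9-fold higher number from compound 1 to compound 4 (0.29 log units; within the scatter), a modest rise. Compound 4 is therefore estimated at 20000 nM, with a likely range from 8000 nM to 50000 nM.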

Compound 4, concentration for 50% growth inhibition: 1380 nM
Estimate against measurement, compound 4: 14-fold (1.16 log units) above, outside the stated range (below it).
By their numbers in this assay, from the lowest: compound 4; then compound 1; then compound 3; then compound 2.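

In this assay every earlier change away from the 4-methylphenyl had raised the number, but the 3-methoxyphenyl reverses that direction, with a 7.5-fold lower number from compound 1 to compound 4 (0.87 log units; beyond the scatter) on the same carbon. The two methoxyphenyl groups themselves stand far apart, with a 19-fold lower number from compound 3 to compound 4 (1.27 log units; beyond the scatter), so at this carbon the outcome depends on where the methoxy sits on the phenyl ring and not merely on its presence; a 38-fold lower number from compound 2 to compound 4 (1.58 log units; beyond the scatter) is now the widest step in the set. Nothing in the data given explains why the 3-methoxyphenyl stands apart.

From the compounds shown here alone, what a 4-methoxyphenyl, a 3-methylphenyl or a 3-aminophenyl would give on that carbon stays open. Also open, going by these compounds, is whether the 3-methoxyphenyl keeps its lead when the 2,3-dihydro-1,4-benzodioxin-6-yl group is replaced.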